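Trifluoromethyl for Fluoro on a Methylated Core

The source may hold more compounds than are shown below. What is called first, only, known or untested is meant among the compounds shown, and "the series" means these compounds.

Three compounds in this set share an amide that links a pyridone-type ring to an ether-bridged bicyclic core, and all three were tested in a functional assay on PC-3 cells (Homo sapiens) for cytotoxicity, read by MTT assay, with a stated time of 72 h; on this read-out lower numbers stand for stronger inhibition and higher numbers for weaker inhibition. Compound 1 `O=C(Nc1ccc(Oc2ccnc3[nH]ccc23)cc1)c1nn(-c2ccc(Cl)c(F)c2)ccc1=O` gives 7780 nM in this assay. Compound 2 `O=C(Nc1ccc(Oc2ccnc3[nH]ccc23)cc1)c1nn(-c2ccc(Cl)c(C(F)(F)F)c2)ccc1=O` carries a trifluoromethyl where compound 1 has a fluoro; the change is trifluoromethyl in place of fluoro on an aromatic carbon, and in this assay compound 2 gives 4630 nM, which is a 1.7-fold lower number from compound 1 to compound 2 (0.23 log units; within the scatter). Compound 3 `Cn1ccc2c(Oc3ccc(NC(=O)c4nn(-c5ccc(Cl)c(F)c5)ccc4=O)cc3)ccnc21` differs from compound 1 at the core, where the change is methyl in place of hydrogen on an aromatic nitrogen; in this assay compound 3 gives 32700 nM, which is a 4.2-fold higher number from compound 1 to compound 3 (0.62 log units; beyond the scatter), and it is the highest number of the three.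

Compound 4 `Cn1ccc2c(Oc3ccc(NC(=O)c4nn(-c5ccc(Cl)c(C(F)(F)F)c5)ccc4=O)cc3)ccnc21` has not yet been measured. It stands to compound 3 exactly as compound 2 stands to compound 1: the change is trifluoromethyl in place of fluoro on an aromatic carbon, on an aromatic carbon of a six-membered aromatic ring of carbon only, ortho to a chloro group and meta to a large group, the same place as in the earlier pair. Within the data shown here, the only guide to this change is the pair of compound 1 and compound 2, where the step was within the usual scatter. Because a 1.7-fold lower number from compound 1 to compound 2 (0.23 log units; within the scatter) was small, the step from compound 3 to compound 4 is expected to be similar, namely a 1.6-fold lower number from compound 3 to compound 4 (0.19 log units; within the scatter). Compound 4 is therefore expected to give about 21000 nM in this assay, with a plausible range from 8000 nM to 55000 nM.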

Compound 4, half-maximal inhibitory concentration: 10300 nM
Compound 4: the middle estimate sits 2.0-fold (0.31 log units) above what was measured; the range from low to high includes it.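

In this assay, trifluoromethyl in place of fluoro on the methylated core gives a 3.2-fold lower number from compound 3 to compound 4 (0.50 log units; beyond the scatter), and although the earlier step lies within the scatter and this one beyond it, the two steps themselves cannot be told apart: the same change on two cores in this assay, a 1.7-fold lower number (0.23 log units; within the scatter) from compound 1 to compound 2 and a 3.2-fold lower number (0.50 log units; beyond the scatter) from compound 3 to compound 4, 1.9-fold (0.28 log units) apart, within the scatter of two such steps. Seen from the other direction, methyl in place of hydrogen on the aromatic nitrogen gives a 2.2-fold higher number from compound 2 to compound 4 (0.35 log units; beyond the scatter), and this step also agrees with its earlier counterpart: the same change on two cores in this assay, a 4.2-fold higher number (0.62 log units; beyond the scatter) from compound 1 to compound 3 and a 2.2-fold higher number (0.35 log units; beyond the scatter) from compound 2 to compound 4, 1.9-fold (0.28 log units) apart, within the scatter of two such steps. Together, the four compounds show that each change had a similar size on both partners tested, so the effects of the two changes here could be treated as roughly additive, but this rests on only one pair of steps per change and shows neither why the numbers move nor that the agreement would hold on any other core.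

The compounds shown leave open what a nitrile or a methoxy group would do in place of the trifluoromethyl, and what an ethyl group or a longer chain would do in place of the methyl on the aromatic nitrogen. They also leave open whether these steps would keep their size on any read-out other than this assay.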